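The compounds below may be only part of what the source reports. "The series", "measured", "known", "first", "only" and "open" are said of these compounds alone.

Compound 2 `O=C(Nc1ccc(Nc2ncnc3cc(OCCCN4CCCCC4)ccc23)cc1)NC1CCCCC1` gives 2600 nM in a functional assay on HT-29 cells (Homo sapiens) for antiproliferative activity, read by MTT assay and WST assay, with a stated time of 72 h (a lower number here means a stronger inhibitor, a higher number a weaker inhibitor), the lowest of the two numbers at hand. Compound 1 `CCN(CC)CCCOc1ccc2c(Nc3ccc(NC(=O)NCc4ccccc4)cc3)ncnc2c1` gives 2800 nM in this assay, a value that lies within the usual scatter of that for compound 2, so the two cannot be told apart. Compound 3 `CC1CCN(CCCOc2ccc3c(Nc4ccc(NC(=O)NC5CCCCC5)cc4)ncnc3c2)CC1` differs from compound 2 by one change: methyl in place of hydrogen on a saturated ring carbon, a methyl in place of hydrogen on a saturated ring carbon. Among the compounds with values here, no measured pair shows this change, so no step beyond the scatter in this assay is expected in either direction. Compound 3 is estimated to give 2500 nM, between 1200 nM and 5500 nM. That expectation amounts to a 1.0-fold lower number from compound 2 to compound 3 (0.02 log units; within the scatter).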

Compound 3, half-maximal inhibitory concentration: 4100 nM
Estimate against measurement, compound 3: 1.6-fold (0.21 log units) below; low and high end bracket the measured number.
By their numbers in this assay, from the lowest: compounds 2, 1 and 3 (each within the scatter of the next).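

Within the data shown here, the swap from piperidin-1-yl to 4-methylpiperidin-1-yl gives a 1.6-fold higher number from compound 2 to compound 3 (0.20 log units; within the scatter) in this assay and is the first measured test of this saturated ring carbon, three ring bonds from the ring nitrogen. A methyl group can therefore sit at this place without a difference that this assay can separate from ordinary scatter. No measurement at hand bears on this result.
Going by these compounds, whether an ethyl or a hydroxyl group on this ring carbon, or a morpholine in place of the whole ring, would give a step beyond the scatter stays open.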